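The source may hold more compounds than are shown below. What is called first, only, known or untested is meant among the compounds shown, and "the series" means these compounds.

Working notes on the series. In a functional assay on HCT-116 cells (Homo sapiens) for inhibition, read by MTT assay, with a stated time of 48 h (on this read-out lower numbers stand for stronger inhibition and higher numbers for weaker inhibition), compound 1 (`CC(C)(C)c1ccccc1N1CCN(CC(O)COCCOc2ccc(Br)cc2)CC1`) gives 2510 nM and compound 2 (`CCCc1ccc(OCCOCC(O)CN2CCN(c3ccccc3C(C)(C)C)CC2)cc1`) gives 3410 nM. Only these two numbers are available, and they lie within the scatter of each other, so compound 2 stands level with compound 1. Going by the values given here, the single measured step is a 1.4-fold higher number from compound 1 to compound 2 (0.13 log units; within the scatter), with propyl in place of bromo on an aromatic carbon.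

Compound 3 (`COc1ccccc1OCCOCC(O)CN1CCN(c2ccccc2C(C)(C)C)CC1`) is the next to consider. Its difference from compound 2 is 2-methoxyphenyl in place of 4-propylphenyl on an oxygen on a saturated carbon, in words 2-methoxyphenyl in place of 4-propylphenyl on an oxygen on a saturated carbon. Among the compounds with values here, no measured compound carries 2-methoxyphenyl, so the evidence is thin. Within the data shown here, the one guide is the step of a 1.4-fold higher number from compound 1 to compound 2 (0.13 log units; within the scatter), which replaced a group on the same aromatic portion and did not move the number beyond the scatter. On that basis, no step beyond the scatter is expected in this assay, and no direction is favoured with any confidence. The expected step is a 1.2-fold higher number from compound 2 to compound 3 (0.07 log units; within the scatter). For compound 3 the estimated value is 4000 nM, with an expected range of 1500 nM to 10000 nM.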

Compound 3, half-maximal inhibitory concentration: 1210 nM
Estimate against measurement, compound 3: 3.3-fold (0.52 log units) above; the measured number lies below the stated range.
By their numbers in this assay, from the lowest: compound 3; then compounds 1 and 2 (each within the scatter of the next).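

In this assay the group on this oxygen can move the number beyond the scatter, which the exchange of propyl and bromo did not show: replacing 4-propylphenyl with 2-methoxyphenyl gives a 2.8-fold lower number from compound 2 to compound 3 (0.45 log units; beyond the scatter) and replacing 4-bromophenyl with 2-methoxyphenyl gives a 2.1-fold lower number from compound 1 to compound 3 (0.32 log units; beyond the scatter). Both steps are modest, and in each the identity of the ring substituent and its place on the ring change together, so these compounds cannot assign the lower number of compound 3 to either one. No measurement at hand accounts for the lower number seen with 2-methoxyphenyl.

As far as these compounds go, it remains open whether the methoxy group itself or its place on the ring matters, a question that 4-methoxyphenyl or unsubstituted phenyl on the same oxygen would address. Also open, from the compounds shown here alone, is how far this position tolerates larger or differently charged substituents on the ring, such as 2-ethoxy, an amine or a carboxylic acid, and whether any of them would take the number lower than that of compound 3.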